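The compounds below may be only part of what the source reports. "The series", "measured", "known", "first", "only" and "open" are said of these compounds alone.

The measured compounds:
compound 1, `COC(=O)/C=C/c1cccc(N(Cc2ccc(-c3cccc(C)c3)cc2)C(=O)C2CCCCC2)c1`: in an assay on isolated protein with Bile acid receptor (Homo sapiens) as the target (a higher number here means that more compound is needed for the effect, a lower number that less compound is needed), compound 1 gives 109 nM
compound 2, `COC(=O)/C=C/c1cccc(N(Cc2ccc(-c3cccc(C)c3)cc2)C(=O)C(C)C)c1`: in this assay compound 2 gives 163 nM
compound 3, `CC(C)(C)OC(=O)/C=C/c1ccc(CN(C(=O)C2CCCCC2)c2cccc(/C=C/C(N)=O)c2)cc1`: in this assay compound 3 gives > 1000 nM

Among the two numbers in this assay compound 1 has the lowest; the nearest is compound 2, with a 1.5-fold higher number from compound 1 to compound 2 (0.17 log units; within the scatter). The third value belongs to compound 3 and is a limit of the assay, not a number (the limit of > 1000 nM in this assay, at which 1 of the 3 values shown sits).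

Compound 4, `CCOC/C=C/c1ccc(CN(C(=O)C2CCCCC2)c2cccc(/C=C/C(=O)OC)c2)cc1`, is still to be measured in this assay. It differs from compound 1 in one place: 3-ethoxyprop-1-en-1-yl in place of 3-methylphenyl on an aromatic carbon. The change sits on an aromatic carbon of a six-membered aromatic ring of carbon only, para to a large group. Among the compounds with values here, the one measured step, from compound 1 to compound 2, concerns the group on the carbonyl carbon and not this position, so it does not bear on the change; compound 3 differs from compound 1 in several places at once and gives only a limit. Within the data shown here, no measured step therefore anchors the expectation, and the change swaps a ring for an open chain. The step from compound 1 to compound 4 is expected to be a 2.8-fold higher number from compound 1 to compound 4 (0.44 log units; beyond the scatter), a modest loss. Compound 4 is therefore estimated at 300 nM, with a range from 100 nM to 1500 nM.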

Compound 4, half-maximal effective concentration: 198000 nM
Compound 4: middle estimate off by 660-fold (2.82 log units), on the low side; measured number outside the range, above it.
By their numbers in this assay, from the lowest: compounds 1 and 2 (each within the scatter of the next); then compound 4.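

In this assay, the position on the aromatic carbon para to a large group proves far more sensitive than the group on the carbonyl carbon: exchanging 3-methylphenyl for 3-ethoxyprop-1-en-1-yl gives a 1800-fold higher number from compound 1 to compound 4 (3.26 log units; beyond the scatter), a large step, whereas the earlier change of cyclohexyl to isopropyl gave a 1.5-fold higher number from compound 1 to compound 2 (0.17 log units; within the scatter), a step within the scatter. Compound 4 thus shows that, in this series, this open chain cannot stand in for the 3-methylphenyl group at this position, although the two differ little in heavy-atom count. Within the data shown here, the single change removes a ring and brings in a double bond outside aromatic rings and an oxygen together, and nothing measured here gives a reason for the size of the step.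

The compounds shown leave open which of these differences accounts for the step, and whether an all-carbon chain such as propyl would behave like the 3-ethoxyprop-1-en-1-yl group. They also leave open how an unsubstituted phenyl ring, a pyridine ring or an amine-bearing chain at this position would compare with compound 1, which gives 109 nM.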